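A few compounds are considered here, and "the series" means these few. Any claim that something is new, unique, unknown or untested is made for them only; others in the source may bear on it.

Compound 3 `CC(C)[C@@H](NC(=O)Nc1ccccc1)C(=O)N1CCC(c2ccc(Cl)cc2)CC1` gives 616 nM in an assay on THP-1 cells for displacement of a labelled ligand from C-C chemokine receptor type 1 (Homo sapiens) (on this read-out lower numbers stand for stronger inhibition and higher numbers for weaker inhibition), the highest number among the three measured. Compound 1 `CC(C)CCC(=O)N[C@@H](C(=O)N1CCC(c2ccc(Cl)cc2)CC1)C(C)C` gives 26 nM and compound 2 `CC(C)[C@@H](NC(=O)CCc1ccc(F)cc1)C(=O)N1CCC(c2ccc(Cl)cc2)CC1` gives 70 nM. The step to compound 4 `CC(C)[C@@H](NC(=O)CC1CC1)C(=O)N1CCC(c2ccc(Cl)cc2)CC1` is cyclopropylmethyl in place of anilino on a carbonyl carbon. Within the data shown here, two measured steps bear on this change, each exchanging a saturated chain for the anilino on the same carbonyl carbon: a 24-fold higher number from compound 1 to compound 3 (1.37 log units; beyond the scatter) and an 8.8-fold higher number from compound 2 to compound 3 (0.94 log units; beyond the scatter), here read in reverse. Both place the anilino on the weak side of the series, so compound 4 is expected to move back toward the numbers of compound 1 and compound 2, with a saturated chain again in that position. The expected step is a 12-fold lower number from compound 3 to compound 4 (1.09 log units; beyond the scatter). Compound 4 is therefore estimated at 50 nM, within 15 nM to 170 nM.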

Compound 4, half-maximal inhibitory concentration: 46 nM
For compound 4 the middle estimate is 1.1-fold (0.04 log units) above the measured one; low and high end bracket the measured number.
By their numbers in this assay, from the lowest: compounds 1, 4 and 2 (each within the scatter of the next, the first and the last beyond it); then compound 3.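

The change from anilino to cyclopropylmethyl on this carbonyl carbon gives a 13-fold lower number from compound 3 to compound 4 (1.13 log units; beyond the scatter), so a group of only four heavy atoms, with a three-membered ring, restores the level of the carbon-linked groups. Size of that group does not separate the carbon-linked compounds: a 1.5-fold lower number from compound 2 to compound 4 (0.18 log units; within the scatter) and a 1.8-fold higher number from compound 1 to compound 4 (0.25 log units; within the scatter). Among the four compounds, only the nitrogen-linked anilino stands apart.

No supporting data bear on why the anilino differs. Open, going by these compounds, is whether the weaker number of compound 3 follows the nitrogen link or its phenyl ring, a question a cyclohexylamino group on that carbon would address.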